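The compounds below may be only part of what the source reports. "The series", "measured", "known", "first", "only" and "open" are said of these compounds alone.

Measured compounds in an in vitro ADME assay on microsomes from liver (Homo sapiens) for metabolic stability; a lower number here means that the compound disappears faster, a higher number that the compound lasts longer:
- compound 1, `COc1ccc(-c2cc(-c3ccc(S(=O)(=O)N(C)C)cc3)cnc2N)cn1`: 0.292 h
- compound 2, `COc1ccc(-c2cc(-c3ccc(S(=O)(=O)NC4CC4)cc3)cnc2N)cn1`: 1.9 h
- compound 3, `COc1ccc(-c2cc(-c3ccc(S(C)(=O)=O)cc3C(F)(F)F)cnc2N)cn1`: > 4.16 h

The value given for compound 3 in this assay is a limit of the assay, not a number; it is the limit of > 4.16 h in this assay, at which 1 of the 3 values shown sits.

Among the two numbers shown, compound 2 stands highest; its nearest neighbour is compound 1, and the step of a 6.5-fold higher number from compound 1 to compound 2 (0.81 log units; beyond the scatter) lies beyond the scatter. Within the data shown here, no further measured step touches compound 2.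

The new compound is compound 4, `COc1ccc(-c2cc(-c3ccc(-n4cncn4)cc3)cnc2N)cn1`. It differs from compound 2 at one place: 1H-1,2,4-triazol-1-yl in place of cyclopropylsulfamoyl on an aromatic carbon. Among the measured compounds shown here, of the measured steps only the step from compound 1 to compound 2 bears on this change, since it also alters the group on this aromatic carbon, and it was modest in size. The change to compound 4 is larger than that one, as the whole sulfamoyl group leaves and an aromatic ring enters, so nothing measured fixes its direction. The step of a 1.3-fold lower number from compound 2 to compound 4 (0.10 log units; within the scatter) is therefore expected to be small, with wide uncertainty either way. For compound 4 a value of 1.5 h is estimated in this assay, within the range 0.45 h to 4.2 h.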

Compound 4, half-life: 3.5 h
For compound 4 the middle estimate is 2.3-fold (0.37 log units) below the measured one, and the stated range covers the measured number.
By their numbers in this assay, from the lowest: compound 1; then compounds 2 and 4 (each within the scatter of the next). At a limit, above all of these: compound 3.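

In this assay this position, on an aromatic carbon para to a large group, keeps its number when the whole cyclopropylsulfamoyl group gives way to 1H-1,2,4-triazol-1-yl: the step is a 1.8-fold higher number from compound 2 to compound 4 (0.27 log units; within the scatter) and leaves the two compounds indistinguishable. Set against the dimethylsulfamoyl group, the same ring gives a 12-fold higher number from compound 1 to compound 4 (1.08 log units; beyond the scatter) and so matches the rise already seen with cyclopropylamino on the sulfonyl sulfur, which places the low number of compound 1 with its dimethylsulfamoyl group and not with the shared core alone, and shows that a sulfonyl sulfur is not needed here for a number of this size. Nothing in the data shown gives a cause for either step.

Going by these compounds, whether a nitrile, a primary amide or another five-membered aromatic ring such as an imidazole or a pyrazole would hold the same level on this carbon remains open. On these data alone, the value of compound 3, > 4.16 h in this assay, is a limit of the assay, and compound 3 differs from the others at more than one place, so the separate contribution of its trifluoromethyl group also remains open.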